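The source may hold more compounds than are shown below. What is called first, only, known or untested is meant among the compounds shown, and "the series" means these compounds.

Compound 1 `N=C(N)c1ccc2[nH]c(-c3cccc(-c4cc(CNC(=O)CO)ccc4O)c3O)cc2c1` and compound 2 `CN(C)CCCC(=O)NCc1ccc(O)c(-c2cccc(-c3cc4cc(C(=N)N)ccc4[nH]3)c2O)c1` share one core and differ in a single place. In an in vivo ADME assay on the whole organism (strain Sprague-Dawley) with Rattus norvegicus as the target (a higher number here means that the compound lasts longer, a lower number that the compound disappears faster), compound 1 gives 1.95 h, while compound 2 gives 0.833 h, a move described by a 2.3-fold lower number from compound 1 to compound 2 (0.37 log units; beyond the scatter). Among the compounds with values here, compound 2 thus holds the lowest of the two numbers seen so far, with compound 1 as its only neighbour. Compound 3 `CCCCCC(=O)NCc1ccc(O)c(-c2cccc(-c3cc4cc(C(=N)N)ccc4[nH]3)c2O)c1` takes the next step: ethyl in place of dimethylamino on a saturated chain carbon, three bonds along the chain from a carbonyl carbon. Within the data shown here, only one measured step bears on it, namely a 2.3-fold lower number from compound 1 to compound 2 (0.37 log units; beyond the scatter), which altered the same chain and was modest in size. Compound 3 drops the dimethylamino that compound 2 carries, and given a 2.3-fold lower number from compound 1 to compound 2 (0.37 log units; beyond the scatter) the new step is expected to run the other way and still modestly, with the expected step being a 1.6-fold higher number from compound 2 to compound 3 (0.19 log units; within the scatter). Compound 3 is accordingly estimated at 1.3 h in this assay, with a likely range from 0.6 h to 2.8 h.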

Compound 3, mean residence time: 1.48 h
The estimate for compound 3 lay 1.1-fold (0.06 log units) below the measured number; measured number inside the range.
By their numbers in this assay, from the lowest: compounds 2, 3 and 1 (each within the scatter of the next, the first and the last beyond it).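

Putting ethyl where compound 2 has dimethylamino gives a 1.8-fold higher number from compound 2 to compound 3 (0.25 log units; within the scatter) in this assay, so this change at the chain end cannot be told apart from the ordinary spread of repeat measurements. The step from the hydroxy end group to the butyl end group, a 1.3-fold lower number from compound 1 to compound 3 (0.12 log units; within the scatter), also stays inside that spread, which leaves compound 3 separated from neither neighbour, even though the earlier step (a 2.3-fold lower number from compound 1 to compound 2 (0.37 log units; beyond the scatter)) is beyond the scatter. No measurement shown here explains these residence times.

On these data alone, it remains open whether a primary amine or a carboxylic acid in this place on the chain would stay within the same spread. A longer chain without any nitrogen is also untested among these compounds, so the effect of chain length alone cannot yet be separated from that of the end group.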